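The source may hold more compounds than are shown below. What is called first, only, known or untested is meant among the compounds shown, and "the series" means these compounds.

Measured compounds:
compound 1, `O=C(COc1ccc(C(=O)/C=C/c2ccccc2Cl)cc1)N[C@H]1CCOC1=O`: 4610 nM
compound 2, `CCOc1ccccc1OCCSC(=S)N[C@H]1CCOC1=O`: 24100 nM
compound 3, `O=C(CNc1ccc(Cl)cc1Cl)N[C@H]1CCOC1=O`: > 64000 nM

The three compounds share a core and were tested in a functional assay on PC-3 cells (Homo sapiens) for antiproliferative activity, read by MTT assay, with a stated time of 72 h; a lower number here means a stronger inhibitor, a higher number a weaker inhibitor. Compound 1 gives 4610 nM in this assay. Compound 2 gives 24100 nM in this assay. Compound 3 stands apart from these two, since its result is not a number but a limit of the assay: in this assay compound 3 gives > 64000 nM. Within the data shown here, it is the one compound that sits at the limit of > 64000 nM in this assay, at which 1 of the 3 values shown sits, so its true potency is not known, only that it lies beyond what the assay resolves.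

Compound 4, `O=C(CNc1ccccc1Cl)N[C@H]1CCOC1=O`, has not yet been measured. It differs from compound 3 in a single place: hydrogen in place of chloro on an aromatic carbon. Among the measured compounds shown here, no step between two measured compounds in this set involves this change, so nothing measured shows how large a step to expect. Since compound 3 already sits at the limit of > 64000 nM in this assay, at which 1 of the 3 values shown sits, the step that the limit leaves unreadable from compound 3 to compound 4 is expected to be small and not clearly in either direction beyond the scatter, with the result most likely again reported as a limit. For compound 4 the estimate in this assay is 80000 nM, with a range from 30000 nM to 200000 nM.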

Compound 4, half-maximal inhibitory concentration: > 64000 nM
Compound 4: only a limit was reported (the forecaster's own chance of this, stated with the estimate: 70%); the middle value does not contradict the limit.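

In this assay compound 4 gives > 64000 nM, which is a limit of the assay and not a number. Among these compounds, compound 3 is also reported only as a limit, so no step from it to compound 4 can be read: the limit of > 64000 nM in this assay, at which 2 of the 4 values shown sit. The compounds shown leave open how potent compound 3 and compound 4 truly are, and what hydrogen in place of chloro does to their activity.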